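The source may hold more compounds than are shown below. What is called first, only, known or untested is meant among the compounds shown, and "the series" means these compounds.

Compound 1 `Clc1ccc(NC2=NCCC3(CCCCC3)S2)cc1` is the point of departure. In a physicochemical assay for lipophilicity, at pH 7.4 (on this read-out higher numbers stand for higher lipophilicity and lower numbers for lower lipophilicity), compound 1 gives 1.34. Compound 2 `CC(C)c1ccc(NC2=NCCC3(CCCCC3)S2)cc1` gives 1.45, and the step of a number 0.11 log units higher from compound 1 to compound 2 (within the scatter) lies within the scatter, so the two cannot be told apart on this assay. Compound 3 `CC(=O)c1ccc(NC2=NCCC3(CCCCC3)S2)cc1` gives 1.88; the step of a number 0.54 log units higher from compound 1 to compound 3 (beyond the scatter) and the step of a number 0.43 log units higher from compound 2 to compound 3 (beyond the scatter) are both beyond the scatter, so compound 3 stands clearly higher than the other two.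

Compound 4 `c1ccc(NC2=NCCC3(CCCCC3)S2)cc1` differs from compound 1 in one place: hydrogen in place of chloro on an aromatic carbon. None of the three measured steps makes exactly this change; each of them exchanges the chloro for another group, or exchanges two such groups, and those exchanges moved this assay by nothing beyond the scatter up to a modest amount. Here the chloro is removed without anything heavier taking its place, and a modest fall beyond the scatter is expected, a number 0.69 log units lower from compound 1 to compound 4 (beyond the scatter). Compound 4 is therefore estimated at 0.65, most likely between 0.2 and 1.1.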

Compound 4, distribution coefficient: 1.69
Compound 4: the middle estimate sits 1.04 log units below what was measured, outside the stated range (above it).
By their numbers in this assay, from the lowest: compounds 1, 2, 4 and 3 (each within the scatter of the next, the first and the last beyond it).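

In this assay, hydrogen in place of chloro on this aromatic carbon gives a clear change (a number 0.35 log units higher from compound 1 to compound 4 (beyond the scatter)), and it goes the same way as the exchanges of chloro for isopropyl and acetyl, even though no heavy atom enters here. This position therefore does not order the compounds by the size of the group it carries: hydrogen cannot be told apart from isopropyl (a number 0.24 log units higher from compound 2 to compound 4 (within the scatter)) or from acetyl (a number 0.19 log units lower from compound 3 to compound 4 (within the scatter)), although those two larger groups differ clearly from each other. No supporting measurement is available to explain this result.

The compounds shown leave open how an amine, a carboxylic acid or a longer chain would behave at this position. They also leave open whether fluoro or bromo would give a step like that of chloro.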